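The source may hold more compounds than are shown below. What is called first, only, known or untested is meant among the compounds shown, and "the series" means these compounds.

Measured compounds:
- compound 1, `CCc1nc(N)c2nn(-c3ccccc3)cc2n1`: 38%
- compound 2, `COc1ccc(CCCc2nc(N)c3nn(-c4ccccc4)cc3n2)cc1`: 1%

In an assay on CHO cells for displacement of a labelled ligand from adenosine receptor A3 (Homo sapiens), read by scintillation counting, tested at 1 uM (on this read-out lower numbers stand for less inhibition and higher numbers for more inhibition at the one concentration tested (going by the name of the read-out)), compound 1 gives 38%. Compound 2 gives 1% in this assay, which is the lowest of the two numbers shown; the only other compound, compound 1, stands higher by a number 37 percentage points lower from compound 1 to compound 2 (beyond the scatter), a drop that lies beyond the scatter.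

Compound 3 `Nc1nc(CCCc2ccccc2O)nc2cn(-c3ccccc3)nc12` differs from compound 2 in one place: 2-hydroxyphenyl in place of 4-methoxyphenyl on a saturated chain carbon, three bonds along the chain from an aromatic carbon.

Among the compounds with values here, only one measured step exists, a number 37 percentage points lower from compound 1 to compound 2 (beyond the scatter), and it tells what happens when a 4-methoxybenzyl group is put onto the chain that carries the aromatic ring in compound 3 as well. That step was large and downward. Within the data shown here, no measured pair shows a 4-methoxyphenyl being swapped for a 2-hydroxyphenyl, so the direction of the present change cannot be read from the numbers. Since compound 2 already sits near the bottom of the scale, the expected step is a number 5 percentage points higher from compound 2 to compound 3 (within the scatter), that is, nothing beyond the scatter. The estimate for compound 3 in this assay is 6%, expected to fall between 0% and 25%.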

Compound 3, a percentage reported as inhibition, at one concentration (the size of the read-out at that concentration, not a potency): 36%
The estimate for compound 3 lay 30 percentage points below the measured number; the measured number lies above the stated range.
By their numbers in this assay, from the lowest: compound 2; then compounds 3 and 1 (each within the scatter of the next).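

In this assay, the far end of the chain turns out to matter a great deal: putting 2-hydroxyphenyl in place of 4-methoxyphenyl, on a saturated chain carbon three bonds along the chain from an aromatic carbon, gives a number 35 percentage points higher from compound 2 to compound 3 (beyond the scatter). The earlier drop therefore cannot be blamed on the presence of an aryl-bearing chain alone, since compound 3 carries the same chain as compound 2 and differs only in the ring at its end. Adding 2-hydroxybenzyl in place of hydrogen gives a number 2 percentage points lower from compound 1 to compound 3 (within the scatter), so at this position a large group can be added with no change beyond the scatter, provided it is this group and not 4-methoxybenzyl.

The swap alters both the ring substituent and where it sits, and it also brings in a hydrogen-bond donor, so the compounds shown leave open which of these differences counts; 4-hydroxyphenyl or 2-methoxyphenyl on the same chain would help separate them, and 2-aminophenyl would test whether the hydroxyl can be replaced. No measurement at hand gives a reason for the gap between these two ring groups.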